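The source may report more compounds than this note shows. Statements on the series, on what has been measured and on what is new or still open speak of the compounds shown alone.

The measured compounds and their readings:

Compound 1, `N/C(=N\NC(=S)N1CCOCC1)c1ccccn1`, gives 7300 nM in a functional assay on HeLa cells (Homo sapiens) for cytotoxicity, read by MTT assay, with a stated time of 72 h; on this read-out higher numbers stand for weaker inhibition and lower numbers for stronger inhibition.
Compound 2, `Cc1ccnc(/C(N)=N/NC(=S)N2CCOCC2)c1`, gives 38500 nM in this assay.
Compound 3, `Cc1ccnc(/C(N)=N/NC(=S)N2CCN(c3ccccn3)CC2)c1`, gives 10500 nM in this assay.

Compound 4, `N/C(=N\NC(=S)N1CCN(c2ccccn2)CC1)c1ccccn1`, has not yet been measured. It differs from compound 3 in one place: hydrogen in place of methyl on an aromatic carbon. The shared core of compound 3 and compound 4 is not the core of compound 1 and compound 2; the difference between the two cores is not broken down here. Yet the very same change has already been tried once on the other core, from compound 2 to compound 1: hydrogen in place of methyl on an aromatic carbon. The position of the change, on an aromatic carbon of a six-membered aromatic ring with 1 nitrogen, meta to a large group and opposite the ring nitrogen, reads alike in both pairs, so this is the same change made on two cores. In this assay that first step gave a 5.3-fold lower number from compound 2 to compound 1 (0.72 log units; beyond the scatter), a modest drop in the number, and therefore a gain in inhibition. Among the three measured compounds, compound 3 sits near compound 1 and clearly apart from compound 2.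

Resting on the single earlier step, compound 4 is expected to show a step of a 3.5-fold lower number from compound 3 to compound 4 (0.54 log units; beyond the scatter), somewhat smaller than the first one since one example is thin ground. The estimate for compound 4 is therefore 3000 nM, most likely between 1000 nM and 9000 nM.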

Compound 4, half-maximal inhibitory concentration: 8600 nM
For compound 4 the middle estimate is 2.9-fold (0.46 log units) below the measured one; the range from low to high includes it.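

In this assay, exchanging methyl for hydrogen on the aromatic carbon opposite the ring nitrogen, which turns 4-methylpyridin-2-yl into pyridin-2-yl, gives a 1.2-fold lower number from compound 3 to compound 4 (0.09 log units; within the scatter), so on this core the change has no effect that can be told apart from the ordinary spread of repeated measurements. The step therefore does not carry over at the same size from one core to the other, and the effect of this small change depends on the core that bears it: the same change on two cores in this assay, a 5.3-fold lower number (0.72 log units; beyond the scatter) from compound 2 to compound 1 and a 1.2-fold lower number (0.09 log units; within the scatter) from compound 3 to compound 4, 4.3-fold (0.64 log units) apart, beyond the scatter of two such steps

This rests on just two pairs of compounds, so it shows that the size of the step can differ between these cores, but not which part of the difference between the cores is responsible, nor how the same change would behave on any third core.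

The compounds shown leave open how an ethyl, a methoxy or a chlorine at this same place would read on each of the two cores, and whether such groups would also give steps that differ from one core to the other. They also leave open whether an amine or a carboxylic acid at this place would follow the methyl pair on either core.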